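Moving the Methyl on the N-Aryl Ring of Compound 3

This account rests on a few compounds, and the source may have more. Where it says the series, first, only, none or still open, it means among the compounds named here.

This account follows three compounds sharing one core and one not yet measured. In an assay on isolated protein for agonist activity at Bile acid receptor (Homo sapiens), read by AlphaScreen, with a stated time of 30 min (a higher number here means a larger maximal response, a lower number a smaller maximal response), compound 1 `Cc1nn(-c2ccccc2C(C)C)c2c1[C@@H](c1ccc(Oc3ccccc3)cc1)S[C@@H](C)C(=O)N2` gives 174%, and compound 2 `COc1cc([C@H]2S[C@@H](C)C(=O)Nc3c2c(C)nn3-c2ccccc2C)ccc1Oc1ccccc1` gives 130%. Compound 3 `Cc1cccc(-n2nc(C)c3c2NC(=O)[C@H](C)S[C@@H]3c2ccc(Oc3ccccc3)cc2)c1` gives 22% in this assay, the lowest of the three numbers shown; its nearest neighbour is compound 2, and the gap to compound 1 is the widest.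

Compound 4 `Cc1ccccc1-n1nc(C)c2c1NC(=O)[C@H](C)S[C@@H]2c1ccc(Oc2ccccc2)cc1` differs from compound 3 in one place: 2-methylphenyl in place of 3-methylphenyl on an aromatic nitrogen.

For the measured compounds named here, one measured step bears on this change. The step of a number 152 percentage points lower from compound 1 to compound 3 (beyond the scatter) shows that exchanging a 2-isopropylphenyl group for the 3-methylphenyl group cost a great deal of maximal response. Compound 4 restores a group of the 2-substituted kind, and compound 2, which carries the same 2-methylphenyl group on the aromatic nitrogen though with a further difference elsewhere, gives 130%. A large upward step beyond the scatter is therefore expected for compound 4, though the two cases on record do not fix its size.

Compound 4 is expected to reach 130% in this assay, with a range from 85% to 175%, corresponding to an expected step of a number 108 percentage points higher from compound 3 to compound 4 (beyond the scatter).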

Compound 4, largest response reached (reported as efficacy), in percent of the reference or control that the assay uses: 118%
The estimate for compound 4 lay 12 percentage points above the measured number, within the range that was stated.
By their numbers in this assay, from the lowest: compound 3; then compound 4; then compound 2; then compound 1.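

In this assay, with the same atoms joined differently, a number 96 percentage points higher from compound 3 to compound 4 (beyond the scatter) shows that the place of the methyl on the phenyl ring carried by the aromatic nitrogen is enough on its own to separate a low number from a high one, which a number 152 percentage points lower from compound 1 to compound 3 (beyond the scatter) could not show, since that step changed the group as well as its place. With the methyl held as 2-methylphenyl, two further single changes have smaller but still measurable effects: a number 56 percentage points lower from compound 1 to compound 4 (beyond the scatter) goes with methyl in place of isopropyl, and a number 12 percentage points lower from compound 2 to compound 4 (beyond the scatter) goes with hydrogen in place of methoxy on an aromatic carbon. No measurement offered here explains why the place of the methyl matters so much to the maximal response.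

The compounds shown leave open whether an ethyl group or a chlorine atom in place of the methyl of the 2-methylphenyl group would hold the high number, and whether a plain phenyl group would fall with compound 3 or stand nearer compound 4. They also leave open how far this result carries over to the methoxy-bearing or isopropyl-bearing members of the series, since neither is seen with a 3-substituted ring.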